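The source may hold more compounds than are shown below. What is called first, only, known or untested is meant among the compounds shown, and "the series" means these compounds.

Measured so far in a functional assay on MCF7 cells (Homo sapiens) for antiproliferative activity, read by sulforhodamine B assay, with a stated time of 48 h; on this read-out higher numbers stand for weaker inhibition and lower numbers for stronger inhibition:
compound 1, `CC(C)c1ccccc1OS(=O)(=O)c1ccc(NC(=O)CCCl)cc1`: 9000 nM
compound 2, `O=C(CCCl)Nc1ccc(S(=O)(=O)Oc2ccccc2I)cc1`: 8900 nM
compound 3, `CCCNC(=O)Nc1ccc(S(=O)(=O)Oc2ccccc2C(C)C)cc1`: 2700 nM

Compound 2 gives the second highest of the three numbers. Its nearest neighbour is compound 1, with a 1.0-fold lower number from compound 1 to compound 2 (0.00 log units; within the scatter); its furthest is compound 3, whose value lies well apart from that of compound 2.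

Compound 4, `O=C(NCCCCl)Nc1ccc(S(=O)(=O)Oc2ccccc2I)cc1`, is not yet measured. It differs from compound 2 in one place: (3-chloropropyl)amino in place of 2-chloroethyl on a carbonyl carbon. Going by the values given here, two measured steps bear on this. The closest parallel is a 3.3-fold lower number from compound 1 to compound 3 (0.52 log units; beyond the scatter), where a chloroethyl amide becomes a propyl urea on the isopropyl-bearing core and the number drops modestly. The step of a 1.0-fold lower number from compound 1 to compound 2 (0.00 log units; within the scatter) shows that exchanging isopropyl for iodo on the aromatic carbon leaves the number where it was, so the amide-to-urea effect seen from compound 1 to compound 3 is taken to carry over onto the core of compound 2. Among the compounds with values here, no measured pair speaks to the chlorine on the entering chain, which is the one part of the change without a precedent here; that adds uncertainty but no direction.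

A modest lowering is therefore expected, a 3.2-fold lower number from compound 2 to compound 4 (0.50 log units; beyond the scatter). For compound 4 the estimate is 2800 nM, with a range from 1200 nM to 6500 nM.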

Compound 4, half-maximal inhibitory concentration: 7600 nM
The estimate for compound 4 lay 2.7-fold (0.43 log units) below the measured number; the measured number lies above the stated range.
By their numbers in this assay, from the lowest: compound 3; then compounds 4, 2 and 1 (each within the scatter of the next).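

In this assay, (3-chloropropyl)amino in place of 2-chloroethyl on the carbonyl carbon gives a 1.2-fold lower number from compound 2 to compound 4 (0.07 log units; within the scatter), so on the iodo-bearing core this change to a urea does not separate the two numbers, whereas propylamino in place of 2-chloroethyl on the isopropyl-bearing core gave a 3.3-fold lower number from compound 1 to compound 3 (0.52 log units; beyond the scatter). Conversion of the amide to a urea at this position is therefore not enough on its own to shift the number, and the step of a 1.0-fold lower number from compound 1 to compound 2 (0.00 log units; within the scatter), read on the amides alone, does not show that the two cores respond alike to a change at this carbonyl carbon. No measurement at hand explains why the two steps differ.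

From the compounds shown here alone, it remains open whether the chlorine on the entering chain or the iodo on the core accounts for the difference between the two steps; propylamino on the iodo-bearing core and (3-chloropropyl)amino on the isopropyl-bearing core would separate these two readings. Going by these compounds, how a longer chain such as butylamino, or a chain ending in an amine instead of chlorine, would read at this carbonyl carbon also remains open.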